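The source may report more compounds than this note shows. Statements on the series, on what has been measured and on what is new or still open speak of the compounds shown alone.

Of the compounds shown here, three built on one shared core have been tested in a functional assay on cells (Burkitts lymphoma cell, Homo sapiens) for antiproliferative activity, read by MTT assay; a higher number here means a weaker inhibitor, a lower number a stronger inhibitor. Compound 1, `c1ccc(/C(=N/Nc2nc3ccccc3o2)C2CC2)nc1`, gives 185 nM in this assay. Compound 2, `C/C(=N\Nc1nc2ccccc2o1)c1cnc(C)cn1`, gives 150 nM in this assay; the two numbers lie within the usual scatter of each other, so although compound 1 holds the higher of the two numbers, that order carries no weight. Compound 3, `C/C(=N\Nc1nc2ccccc2o1)c1cccnc1`, is reported only as a limit of the assay, > 100000 nM, with no number behind it. the limit of > 100000 nM in this assay, at which 1 of the 3 values shown sits, marks where that limit lies, and one of the three values sits at it.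

Compound 4, `CC(C)(C)/C(=N\Nc1nc2ccccc2o1)c1ccccn1`, has not yet been measured. It differs from compound 1 in one place: tert-butyl in place of cyclopropyl on a carbon with a double bond to nitrogen. Among the measured compounds shown here, no pair of measured compounds shows the effect of such a change, so the size of the step can only be estimated. Both compound 1 and compound 2 are active in this assay, while the loss of activity in compound 3 goes with a change of the aromatic ring rather than of this group. The move to tert-butyl lies outside what the measured set covers, so a modest weakening is expected, a 2.2-fold higher number from compound 1 to compound 4 (0.33 log units; beyond the scatter), though a value within the scatter would not surprise. For compound 4 the expected value in this assay is 400 nM, with a likely range from 120 nM to 3000 nM.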

Compound 4, half-maximal inhibitory concentration: > 10000 nM
Compound 4 gave a limit, no number; the forecaster's own chance of this, stated with the estimate: 15%; middle value at least 25-fold (1.39 log units) away from the limit.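

The group on the carbon with a double bond to nitrogen turns out to matter a great deal in this assay: tert-butyl in place of cyclopropyl gives an at least 54-fold higher number from compound 1 to compound 4 (1.73 log units; beyond the scatter). Among the compounds shown here, the earlier compounds held no pair that differed in this place alone, so this is the first direct reading of what a change there can do, and here it is a change between two groups made only of carbon, with no hydrogen-bond donors or acceptors on either side. The result for compound 4 is a limit of the assay and not a number, so the step shows only how large the loss is at the least: the limit of > 10000 nM in this assay, at which 1 of the 4 values shown sits.

Only these two groups can be compared in this place on the same core, so the compounds shown cannot tell whether the loss goes with the three-membered ring leaving, with the extra carbon entering, or with something else. As far as these compounds go, how an isopropyl group, a longer chain or an amine would behave in this place also stays open, and such groups would show whether activity falls away gradually or all at once.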